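The compounds below may be only part of what the source reports. "The series", "measured", "known", "first", "only" and "open" are said of these compounds alone.

Measured compounds:
- compound 1, `Cc1cn([C@@H]2O[C@H](CO[Si](C)(C)C(C)(C)C)[C@@]3(OS(=O)(=O)C(c4ccsc4)=C3N)[C@H]2O[Si](C)(C)C(C)(C)C)c(=O)n(C)c1=O`: in a functional assay on CCRF-CEM cells (Homo sapiens) (on this read-out higher numbers stand for lower toxicity in this test and lower numbers for higher toxicity in this test), compound 1 gives 33000 nM
- compound 2, `C=CCC1=C(N)[C@@]2(OS1(=O)=O)[C@@H](CO[Si](C)(C)C(C)(C)C)O[C@@H](n1cc(C)c(=O)n(C)c1=O)[C@@H]2O[Si](C)(C)C(C)(C)C`: in this assay compound 2 gives 45000 nM
- compound 3, `Cc1cn([C@@H]2O[C@H](CO[Si](C)(C)C(C)(C)C)[C@@]3(OS(=O)(=O)C(Cl)=C3N)[C@H]2O[Si](C)(C)C(C)(C)C)c(=O)[nH]c1=O`: in this assay compound 3 gives 7000 nM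

Compound 3 has the lowest number of the three, which here means the strongest effect on the cells; compound 1 is nearest to it and compound 2 furthest, and both gaps lie beyond the scatter. Compound 4, `Cc1cn([C@@H]2O[C@H](CO[Si](C)(C)C(C)(C)C)[C@@]3(OS(=O)(=O)C(Br)=C3N)[C@H]2O[Si](C)(C)C(C)(C)C)c(=O)[nH]c1=O`, is not yet measured. It differs from compound 3 in one place: bromo in place of chloro on a double-bonded ring carbon.

For the measured compounds named here, only one measured step touches the same double-bonded ring carbon, and it is a 1.4-fold higher number from compound 1 to compound 2 (0.13 log units; within the scatter), an exchange of two much larger groups that left the number essentially unchanged. Going by the values given here, no measured pair shows a swap of one halogen for another, so there is nothing to point to a shift in either direction. The expectation for this assay is therefore a step from compound 3 to compound 4 of no change at the digits printed from compound 3 to compound 4 (within the scatter), within the scatter. Compound 4 is expected to give about 7000 nM, within a range from 3000 nM to 16000 nM.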

Compound 4, half-maximal cytotoxic concentration: 17000 nM
Compound 4: the middle estimate sits 2.4-fold (0.39 log units) below what was measured; measured number outside the range, above it.
By their numbers in this assay, from the lowest: compound 3; then compounds 4, 1 and 2 (each within the scatter of the next, the first and the last beyond it).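

In this assay, the double-bonded ring carbon next to the ring sulfur proves sensitive to a swap between two halogens, with a 2.4-fold higher number from compound 3 to compound 4 (0.39 log units; beyond the scatter), a move toward lower toxicity in this test. For the compounds shown here, the only earlier step at this carbon, a 1.4-fold higher number from compound 1 to compound 2 (0.13 log units; within the scatter), exchanged thiophen-3-yl for allyl on a different core and stayed within the scatter, so a large change of group there gave no readable shift, whereas this single-atom change does. No measurement shown explains why bromo gives a higher number than chloro here.

Going by these compounds, two halogens cannot establish a trend, so it remains open where fluoro, iodo or a non-halogen group such as methyl or nitrile would fall at this carbon. On these data alone, it is also open whether the same exchange of chloro for bromo would give a similar step on the core of compound 1.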